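The source may report more compounds than this note shows. Statements on the series, on what has been measured and on what is new or still open speak of the compounds shown alone.

In a functional assay for inhibition, with Rattus norvegicus as the target (a higher number here means a weaker inhibitor, a lower number a stronger inhibitor), the measured compounds are:

- Compound 1 `C[C@@H](/N=c1\c(O)c(O)\c1=N/c1ccc(C#N)cc1)C(C)(C)C`: 370 nM; 24300 nM (2 entries)
- Compound 2 `C/N=c1\c(O)c(O)\c1=N/c1ccc(C#N)cc1`: > 30000 nM (a limit)
- Compound 3 `CCCCCCC/N=c1\c(O)c(O)\c1=N/c1ccc(C#N)cc1`: > 30000 nM (a limit)

Compound 3 gives no number, only > 30000 nM, which is a limit. It shares that limit with compound 2, as the limit of > 30000 nM in this assay, at which 2 of the 3 values shown sit, records. Among the measured compounds shown here, the only measured step is a step that the two limits leave unreadable from compound 2 to compound 3, so it offers no size to carry forward.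

Compound 4 `CCC(C)(C)/N=c1\c(O)c(O)\c1=N/c1ccc(C#N)cc1` has not yet been measured. It differs from compound 3 by one change: 1,1-dimethylpropyl in place of heptyl on a double-bonded nitrogen. The chain on the double-bonded nitrogen is thus replaced by a shorter, branched group.

For the measured compounds named here, the nearest guide is compound 1, the only compound here with numerical readings, at 370 nM; 24300 nM (2 entries). Its group is also branched, so compound 4 may well read on scale in this assay rather than at the limit. That guide is weak, however, since the several entries of compound 1 in this assay, 370 nM; 24300 nM (2 entries) shows entries for one compound that lie far apart. An estimated step of an at least 10-fold lower number from compound 3 to compound 4 (1.00 log units; beyond the scatter) is expected, toward a stronger inhibitor, and a result at the limit remains quite possible.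

For compound 4 the expected value is 3000 nM, with an estimated range from 300 nM to 30000 nM.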

Compound 4, half-maximal inhibitory concentration: > 30000 nM
Compound 4: a limit, no number; the forecaster's own chance of this, stated with the estimate: 35%; middle value at least 10-fold (1.00 log units) away from the limit.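

In this assay compound 4 gives > 30000 nM, which is a limit and not a number, so the steps among compound 2, compound 3 and compound 4 cannot be read. The compounds shown leave open whether any group on the double-bonded nitrogen other than that of compound 1 gives an on-scale reading, and where compound 1 itself stands: the several entries of compound 1 in this assay, 370 nM; 24300 nM (2 entries)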